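Pyrrolidine nitrogen substituent: cyclohexylmethyl to (furan-3-yl)methyl

The source may hold more compounds than are shown below. What is called first, only, known or untested is meant among the compounds shown, and "the series" means these compounds.

The series shares one core carrying a chlorophenyl group and a urea-linked pyrrolidine whose amine nitrogen bears a variable substituent. Compound 1 `CN(C(=O)N1CC[C@H](n2cnc3cc(-c4ccc(Cl)cc4)sc3c2=O)C1)[C@H]1CCN(C2CCC2)C1` carries cyclobutyl on that nitrogen; in a functional assay for antagonist activity at melanin-concentrating hormone receptor 1 (Homo sapiens), read by GTPgammaS binding (on this read-out lower numbers stand for stronger inhibition and higher numbers for weaker inhibition), compound 1 gives 9 nM. Among the measured compounds shown here, compound 2 `CN(C(=O)N1CC[C@H](n2cnc3cc(-c4ccc(Cl)cc4)sc3c2=O)C1)[C@H]1CCN(CC2CCCCC2)C1` carries cyclohexylmethyl instead; in this assay compound 2 gives 53 nM, the highest of the two numbers so far, separated from compound 1 by a 5.9-fold higher number from compound 1 to compound 2 (0.77 log units; beyond the scatter).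

Compound 3 `CN(C(=O)N1CC[C@H](n2cnc3cc(-c4ccc(Cl)cc4)sc3c2=O)C1)[C@H]1CCN(Cc2ccoc2)C1` differs from compound 2 in one place: furan-3-yl in place of cyclohexyl on a saturated chain carbon bound to an amine nitrogen in a ring. The methylene between the ring and the amine nitrogen stays.

For the measured compounds named here, only the step from compound 1 to compound 2 bears on this change, and it only shows that exchanging the substituent on this nitrogen moves this assay by a modest amount, as a 5.9-fold higher number from compound 1 to compound 2 (0.77 log units; beyond the scatter). Going by the values given here, no measured pair exchanges a non-aromatic ring for an aromatic one at this place, so the direction is uncertain; a modest move toward the lower number of compound 1 is expected rather than a further rise. Compound 3 is therefore estimated at 30 nM, within 8 nM to 110 nM, an expected step of a 1.8-fold lower number from compound 2 to compound 3 (0.25 log units; within the scatter).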

Compound 3, half-maximal inhibitory concentration: 15 nM
Beside the measured number, compound 3's estimate is 2.0-fold (0.30 log units) above it; measured number inside the range.
By their numbers in this assay, from the lowest: compounds 1 and 3 (each within the scatter of the next); then compound 2.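

In this assay, the exchange of cyclohexyl for furan-3-yl on the saturated chain carbon gives a 3.5-fold lower number from compound 2 to compound 3 (0.55 log units; beyond the scatter), so the substituent's ring can change the read-out at this place even with the methylene kept, which the earlier step could not show. Compared with the cyclobutyl group on the same amine nitrogen, (furan-3-yl)methyl gives a 1.7-fold higher number from compound 1 to compound 3 (0.22 log units; within the scatter), so a methylene-linked ring on this nitrogen does not by itself go with the higher number seen for compound 2. No measurement available here accounts for either step.

The step from compound 2 to compound 3 changes ring size, aromatic character and the ring oxygen together, so the compounds shown cannot assign the shift to any one of these. Pairs such as cyclopentylmethyl against (tetrahydrofuran-3-yl)methyl, or benzyl against (furan-2-yl)methyl, would separate these features and show whether the ring oxygen and its location matter on this nitrogen.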